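The source may report more compounds than this note shows. Statements on the series, on what has been measured and on what is new or still open speak of the compounds shown alone.

Measured so far in a functional assay on HeLa cells (Homo sapiens) for cytotoxicity, read by sulforhodamine B assay, with a stated time of 48 h; a lower number here means a stronger inhibitor, a higher number a weaker inhibitor:
- compound 1 `CC(=O)OC[C@H]1O[C@@H](n2cc(CN3C(=O)/C(=C\c4ccccc4)c4ccccc43)nn2)[C@H](OC(C)=O)[C@@H](OC(C)=O)[C@@H]1OC(C)=O` gives 33300 nM
- compound 2 `CC(=O)OC[C@H]1O[C@@H](n2cc(CN3C(=O)/C(=C/c4ccccc4)c4ccccc43)nn2)[C@H](OC(C)=O)[C@@H](OC(C)=O)[C@@H]1OC(C)=O` gives 37100 nM
- compound 3 `CC(=O)OC[C@H]1O[C@@H](n2cc(CN3C(=O)/C(=C/c4ccc(C)cc4)c4ccccc43)nn2)[C@H](OC(C)=O)[C@@H](OC(C)=O)[C@@H]1OC(C)=O` gives 85600 nM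

Compound 3 stands highest of the three numbers in this assay. Its nearest neighbour is compound 2, reached by a 2.3-fold higher number from compound 2 to compound 3 (0.36 log units; beyond the scatter), a methyl in place of hydrogen on an aromatic carbon; compound 1 lies a little further off, as the two values show.

Compound 4 `CC(=O)OC[C@H]1O[C@@H](n2cc(CN3C(=O)/C(=C\c4ccc(C)cc4)c4ccccc43)nn2)[C@H](OC(C)=O)[C@@H](OC(C)=O)[C@@H]1OC(C)=O` is the next step: the two compounds have the same atoms and bonds and differ only in configuration as drawn: 1 of 6 stereo elements differ; a double bond is drawn E in compound 3 and Z in compound 4. Within the data shown here, the one measured step that bears on this change is a 1.1-fold higher number from compound 1 to compound 2 (0.05 log units; within the scatter), where the same double bond was turned the other way, because the fact that compounds 1 and 2 differ only in the configuration as drawn it is the only difference between those two compounds. That step was within the scatter. Compound 4 is therefore expected to show no change beyond the scatter in this assay, a 1.0-fold lower number from compound 3 to compound 4 (0.02 log units; within the scatter). Compound 4 is estimated at 82000 nM, with a range from 41000 nM to 164000 nM.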

Compound 4, half-maximal inhibitory concentration: > 100000 nM
Compound 4: no number, only a limit (the forecaster's own chance of this, stated with the estimate: 5%); middle value at least 1.2-fold (0.08 log units) away from the limit.
By their numbers in this assay, from the lowest: compounds 1 and 2 (each within the scatter of the next); then compound 3. At a limit, above all of these: compound 4.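

In this assay compound 4 gives > 100000 nM, which is a limit of the assay and not a number. The turn of the double bond with the methyl in place, an at least 1.1-fold higher number from compound 3 to compound 4 (0.06 log units; that floor lies within the scatter), has a floor that does not clear the scatter, so no effect of configuration can yet be claimed. The methyl in place of hydrogen on an aromatic carbon, an at least 3.0-fold higher number from compound 1 to compound 4 (0.47 log units; beyond the scatter), now also goes to a higher number with the double bond drawn Z, as it did with the double bond drawn E: the same change on two cores in this assay, a 2.3-fold higher number (0.36 log units; beyond the scatter) from compound 2 to compound 3 and an at least 3.0-fold higher number (0.47 log units; beyond the scatter) from compound 1 to compound 4; the limit leaves it open whether they differ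

Going by these compounds, it remains open how far compound 4 truly lies from compound 3. On these data alone, it also remains open whether an amine or a carboxylic acid in place of that methyl would move the number the same way.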